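Chloro on the Anilide Phenyl of a Coumarin Carboxamide

The source may hold more compounds than are shown below. What is called first, only, known or untested is meant among the compounds shown, and "the series" means these compounds.

Among the measured compounds shown here, compound 1 `Cc1ccc2oc(=O)c(C(=O)Nc3ccccc3)cc2c1` is one of two compounds measured in an assay on cells for inhibition of Amine oxidase [flavin-containing] B (Homo sapiens), read by fluorescence and Amplex Red, using microsomes, with a stated time of 15 min (a higher number here means a weaker inhibitor, a lower number a stronger inhibitor), where compound 1 gives 15.3 nM. Compound 2 `Cc1cccc(NC(=O)c2coc3ccc(C)cc3c2=O)c1` gives 17.1 nM, and the two numbers lie within the usual scatter of each other. Compound 3 `Cc1ccc2oc(=O)c(C(=O)Nc3ccc(Cl)cc3)cc2c1` differs from compound 1 by the change (chloro in place of hydrogen on an aromatic carbon). For the measured compounds named here, no measured pair shows the effect of this change here, so only a modest step, if any, is expected; the value of compound 3 is estimated at 10 nM with a range from 3 nM to 35 nM. The expected step of a 1.5-fold lower number from compound 1 to compound 3 (0.18 log units; within the scatter) would stay close to the scatter.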

Compound 3, half-maximal inhibitory concentration: 11.1 nM
Beside the measured number, compound 3's estimate is 1.1-fold (0.05 log units) below it; the range from low to high includes it.
By their numbers in this assay, from the lowest: compounds 3, 1 and 2 (each within the scatter of the next).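

Going from phenyl to 4-chlorophenyl gives, in this assay, a 1.4-fold lower number from compound 1 to compound 3 (0.14 log units; within the scatter), the first measured step at this position. A single chlorine can therefore sit on this ring carbon, para to a large group, without a step that stands out from repeat measurements. No other measurement here offers an explanation for this result.

Still open, going by these compounds, is whether a methoxy group, an amine or a carboxylic acid at this carbon would also stay within the scatter. On these data alone, it is equally open whether chloro would give a similar result on the core of compound 2.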